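This account rests on a few compounds, and the source may have more. Where it says the series, first, only, none or still open, it means among the compounds named here.

Compound 1 `COc1ccc(-c2cc(NC(=S)NNC(=O)c3ccc(C)cc3)cs2)cc1` in a functional assay on Hs 683 cells (Homo sapiens) for inhibition, read by colorimetric assay and MTT assay, with a stated time of 72 h (on this read-out lower numbers stand for stronger inhibition and higher numbers for weaker inhibition), gives 30000 nM. Compound 2 `Cc1ccc(C(=O)NNC(=S)Nc2csc(-c3ccc(C)cc3)c2)cc1` in this assay gives 40000 nM. Compound 3 `COc1cc(C(=O)NNC(=S)Nc2csc(-c3ccccc3)c2)cc(OC)c1OC` in this assay gives 42000 nM.

Compound 2 stands second highest of the three numbers, and its value lies within the scatter of both compound 1 and compound 3. For the measured compounds named here, the one step that touches the same aromatic carbon, a 1.3-fold higher number from compound 1 to compound 2 (0.12 log units; within the scatter), was a methyl in place of methoxy and stayed within the scatter. Compound 4 `Cc1ccc(-c2cc(NC(=S)NNC(=O)c3ccc(O)cc3)cs2)cc1` differs from compound 2 by hydroxy in place of methyl on an aromatic carbon. Going by the values given here, no measured step swaps methyl for hydroxy, so the only bearing evidence is the flat step at this position. Compound 4 is therefore expected to show no change at the digits printed from compound 2 to compound 4 (within the scatter) in this assay, no step beyond the scatter. The estimate for compound 4 is 40000 nM, between 18000 nM and 90000 nM.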

Compound 4, half-maximal inhibitory concentration: 49000 nM
For compound 4 the middle estimate is 1.2-fold (0.09 log units) below the measured one; the range from low to high includes it.
By their numbers in this assay, from the lowest: compounds 1, 2, 3 and 4 (each within the scatter of the next).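

Hydroxy in place of methyl, on a different aromatic ring from the one altered by methyl in place of methoxy, gives a 1.2-fold higher number from compound 2 to compound 4 (0.09 log units; within the scatter) in this assay. So a second aromatic position now tolerates an exchange, here 4-methylphenyl to 4-hydroxyphenyl, that brings in a hydrogen-bond donor and acceptor, with the number staying within the scatter. No measurement shown here accounts for this result.

The compounds shown leave open whether an amine or a carboxylic acid at this place would also stay within the scatter. They also leave open whether any group here can move the number beyond it.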